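Three measured pyridine-linked phenols and one awaiting its number

The compounds below may be only part of what the source reports. "The series", "measured", "known", "first", "only" and "open" are said of these compounds alone.

Of the compounds shown here, three have been measured in a functional assay on HCT-15 cells (Homo sapiens) for inhibition; on this read-out lower numbers stand for stronger inhibition and higher numbers for weaker inhibition: compound 1 `Oc1ccc(-c2cc(-c3ccccc3F)cc(-c3cccc(O)c3)n2)cc1`, compound 2 `Oc1ccc(-c2cc(-c3ccccc3F)cc(-c3ccc(O)cc3)n2)cc1` and compound 3 `Oc1cccc(-c2cc(-c3ccc(OC(F)(F)F)cc3)cc(-c3ccccc3O)n2)c1`. In this assay compound 1 gives 5630 nM. In this assay compound 2 gives 8180 nM, and the change between them, (4-hydroxyphenyl in place of 3-hydroxyphenyl on an aromatic carbon), produced a 1.5-fold higher number from compound 1 to compound 2 (0.16 log units; within the scatter). In this assay compound 3 gives 9410 nM, a number that stands within the scatter of both compound 1 and compound 2, so no order among the three can be drawn from these values.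

Compound 4 `Oc1ccc(-c2cc(-c3ccc(OC(F)(F)F)cc3)cc(-c3ccccc3O)n2)cc1` has not yet been measured in this assay. It is derived from compound 3 by 4-hydroxyphenyl in place of 3-hydroxyphenyl on an aromatic carbon. Among the compounds with values here, this is the same kind of change as the one from compound 1 to compound 2, though not the same: in compound 1 the changed carbon is meta to a 2-fluorophenyl group and meta to a 4-hydroxyphenyl group, whereas in compound 3 it is meta to a 2-hydroxyphenyl group and meta to a large group. The difference between the two cores themselves is not broken down here.

The expected step from compound 3 to compound 4 in this assay is a 1.3-fold higher number from compound 3 to compound 4 (0.11 log units; within the scatter), a size set beside the earlier one because a 1.5-fold higher number from compound 1 to compound 2 (0.16 log units; within the scatter) stayed within the scatter. Compound 4 is therefore expected to give 12000 nM, estimated between 5000 nM and 30000 nM.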

Compound 4, half-maximal inhibitory concentration: > 50000 nM
Compound 4 ended at the assay's limit; the forecaster's own chance of this, stated with the estimate: 20%; middle value at least 4.1-fold (0.61 log units) away from the limit.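

In this assay compound 4 gives > 50000 nM, which is a limit of the assay and not a number. Read against that limit, moving the hydroxyl-bearing ring from 3-hydroxyphenyl to 4-hydroxyphenyl gives an at least 5.3-fold higher number from compound 3 to compound 4 (0.72 log units; beyond the scatter), and the change did not carry over with the same size from one core to the other: the same change on two cores in this assay, a 1.5-fold higher number (0.16 log units; within the scatter) from compound 1 to compound 2 and an at least 5.3-fold higher number (0.72 log units; beyond the scatter) from compound 3 to compound 4, at least 3.6-fold (0.56 log units) apart, beyond the scatter of two such steps This shows that the small step seen on the core of compound 1 cannot be taken as a guide to the step on the core of compound 3, but it does not give the true size of the second step, which has only a lower bound, and it does not show why the two cores respond differently.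

The two cores differ in more than one group, so the compounds shown leave open whether the larger step goes with the 2-hydroxyphenyl group, with the trifluoromethoxy-bearing group, or with the two together in place of the 2-fluorophenyl group and the other hydroxyphenyl group. They also leave open whether an amine or a carboxylic acid in place of the hydroxyl on the moved ring would follow compound 3 or compound 4 in this series.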